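Methylating the Ring Nitrogen of Compound 3

A few compounds are considered here, and "the series" means these few. Any claim that something is new, unique, unknown or untested is made for them only; others in the source may bear on it.

Compound 1, `O=S(=O)(c1cccc(F)c1)c1cn(C2CCNC2)c2ncccc12`: 278 nM
Compound 2, `CN1CCCC(n2cc(S(=O)(=O)c3cccc(C(F)(F)F)c3)c3cccnc32)C1`: 49 nM
Compound 3, `O=S(=O)(c1cccc(F)c1)c1cn(C2CCCNC2)c2ncccc12`: 67 nM

All three were measured in a functional assay on HeLa cells for agonist activity at 5-hydroxytryptamine receptor 6 (Homo sapiens), read by cAMP accumulation and immunoassay; a higher number here means that more compound is needed for the effect, a lower number that less compound is needed. Compound 3 stands second highest of the three numbers; its nearest neighbour is compound 2, which lies within the scatter of it, while compound 1 sits farther away, beyond the scatter. Going by the values given here, the only measured step between two compounds that differ in one place is a 4.1-fold lower number from compound 1 to compound 3 (0.62 log units; beyond the scatter), a modest change that comes from enlarging the saturated ring.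

Compound 4, `CN1CCCC(n2cc(S(=O)(=O)c3cccc(F)c3)c3cccnc32)C1`, is made from compound 3 by methyl in place of hydrogen on an amine nitrogen in a ring. Among the compounds with values here, no measured step covers this exact change. The closest guide is compound 2, which carries the same methyl on its ring nitrogen but a trifluoromethyl group rather than fluorine on the aryl ring; its value sits within the scatter of compound 3. On that basis, compound 4 is expected to land close to compound 3, with a 1.1-fold lower number from compound 3 to compound 4 (0.05 log units; within the scatter) remaining inside the scatter. The estimate for compound 4 in this assay is 60 nM, with a range from 20 nM to 180 nM.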

Compound 4, half-maximal effective concentration: 306 nM
Estimate against measurement, compound 4: 5.1-fold (0.71 log units) below; measured number outside the range, above it.
By their numbers in this assay, from the lowest: compounds 2 and 3 (each within the scatter of the next); then compounds 1 and 4 (each within the scatter of the next).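

In this assay, methyl in place of hydrogen on the amine nitrogen in the ring is far from a neutral change, giving a 4.6-fold higher number from compound 3 to compound 4 (0.66 log units; beyond the scatter) for one added carbon. With that methyl present, the aryl group also counts: fluoro in place of trifluoromethyl gives a 6.2-fold higher number from compound 2 to compound 4 (0.80 log units; beyond the scatter) on this step, while 1-methylpiperidin-3-yl in place of pyrrolidin-3-yl gives a 1.1-fold higher number from compound 1 to compound 4 (0.04 log units; within the scatter) and so cancels what the larger ring alone brought to compound 3. Nothing available explains why the added methyl raises the number.

The compounds shown leave open whether a longer chain on that nitrogen, such as ethyl or propyl, or an acetyl group would behave as methyl does. They also leave open whether methyl has the same effect when trifluoromethyl sits on the aryl ring.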